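The compounds below may be only part of what the source reports. "The series", "measured", "known", "first", "only" and "open" are said of these compounds alone.

Working notes on the amide series. All three measured compounds share the core shown in compound 1 `O=C(Nc1ccc(Cl)c(-c2nnc3c(Cl)cccn23)c1)c1ccccc1` and differ only in the aryl group on the carbonyl carbon. In a functional assay on MDA-MB-468 cells (Homo sapiens) for antiproliferative activity, read by MTT assay, with a stated time of 72 h (a higher number here means a weaker inhibitor, a lower number a stronger inhibitor), compound 1 reaches only > 100000 nM, which is a limit of the measurement and not a number (the limit of > 100000 nM in this assay, at which 1 of the 3 values shown sits). Compound 2 `O=C(Nc1ccc(Cl)c(-c2nnc3c(Cl)cccn23)c1)c1cccc(Cl)c1` gives 54800 nM in this assay. Compound 3 `Cc1cc(Cl)ccc1C(=O)Nc1ccc(Cl)c(-c2nnc3c(Cl)cccn23)c1` gives 34300 nM in this assay, the lowest of the two numbers obtained, but its step from compound 2 is a 1.6-fold lower number from compound 2 to compound 3 (0.20 log units; within the scatter), so the two cannot be placed in order. The steps from the unsubstituted amide are an at least 1.8-fold lower number from compound 1 to compound 2 (0.26 log units; that floor lies within the scatter) and an at least 2.9-fold lower number from compound 1 to compound 3 (0.46 log units; beyond the scatter); both substituted phenyl groups give lower numbers than the bare phenyl.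

Compound 4 `O=C(Nc1ccc(Cl)c(-c2nnc3c(Cl)cccn23)c1)c1ccon1` carries 1,2-oxazol-3-yl in place of 4-chloro-2-methylphenyl on a carbonyl carbon. Among the compounds with values here, no measured step covers this change: all three steps move between phenyl groups, and the bare phenyl of compound 1 sits at a limit. The expectation is that removing the chloro and methyl substituents and replacing the six-membered ring with the smaller 1,2-oxazol-3-yl moves the number back toward that of compound 1, a step of a 2.6-fold higher number from compound 3 to compound 4 (0.42 log units; beyond the scatter) expected, with a real chance that only a limit is obtained. Compound 4 is therefore estimated at 90000 nM, within 30000 nM to 300000 nM.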

Compound 4, half-maximal inhibitory concentration: > 100000 nM
Compound 4: only a limit was reported; the forecaster's own chance of this, stated with the estimate: 45%; middle value at least 1.1-fold (0.04 log units) from the limit.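

Compound 4 ends at a limit and not a number, which makes it the second amide in the series to do so: the limit of > 100000 nM in this assay, at which 2 of the 4 values shown sit.

In this assay, within the data shown here, replacing 4-chloro-2-methylphenyl on the carbonyl carbon gives an at least 2.9-fold higher number from compound 3 to compound 4 (0.46 log units; beyond the scatter), the first step that moves away from a substituted phenyl group and lies beyond the scatter, while replacing 3-chlorophenyl gives an at least 1.8-fold higher number from compound 2 to compound 4 (0.26 log units; that floor lies within the scatter), which on its own does not separate the two compounds. The step between compound 1 and compound 4 cannot be read, as both stand at limits, so no order can be given between the bare phenyl and 1,2-oxazol-3-yl, and among the four compounds shown, numbers are obtained only with the two substituted phenyl groups, compound 2 and compound 3.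

On these data alone, it remains open whether the five-membered ring or the loss of the chloro and methyl substituents accounts for the step from compound 3, a question that a 1,2-oxazol-3-yl bearing a methyl group or a chloro substituent would address. As far as these compounds go, how a pyridyl ring, or a phenyl group bearing an amine or a carboxylic acid, would read at this position also stays open.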